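The source may report more compounds than this note shows. Statements on the series, on what has been measured and on what is new or still open speak of the compounds shown alone.

Measured so far in this series: compound 1 `Cc1cc(C)nc(Oc2ccc(NC(=O)Nc3ccc(OC(F)(F)F)cc3)cc2)n1`, compound 2 `Cc1cc(C)nc(Sc2ccc(NC(=O)Nc3ccccc3)cc2)n1`, compound 3 `Cc1cc(C)nc(Sc2ccc(NC(=O)Nc3ccc(OC(F)(F)F)cc3)cc2)n1`.

In a functional assay on MGC-803 cells (Homo sapiens) for cytotoxicity, read by MTT assay, with a stated time of 3 days (a higher number here means a weaker inhibitor, a lower number a stronger inhibitor), compound 1 reaches only the assay limit, > 50000 nM. Compound 2 gives 40100 nM and compound 3 gives 13800 nM, so compound 3 holds the lowest of the two numbers shown. The two steps leading to it are an at least 3.6-fold lower number from compound 1 to compound 3 (0.55 log units; beyond the scatter) and a 2.9-fold lower number from compound 2 to compound 3 (0.46 log units; beyond the scatter).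

Compound 4 `Cc1cc(C)nc(Sc2ccc(NC(=O)Nc3ccc(Cl)cc3)cc2)n1` differs from compound 3 by chloro in place of trifluoromethoxy on an aromatic carbon. The step that bears on this position is a 2.9-fold lower number from compound 2 to compound 3 (0.46 log units; beyond the scatter), which shows that the group there moves the number by a modest amount. Chloro is neither hydrogen nor trifluoromethoxy, so the step is expected to be small, at most modest, and more likely toward a higher number. Compound 4 is therefore expected at 20000 nM, between 8000 nM and 50000 nM, a step of a 1.4-fold higher number from compound 3 to compound 4 (0.16 log units; within the scatter).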

Compound 4, half-maximal inhibitory concentration: 26100 nM
Compound 4: the middle estimate sits 1.3-fold (0.12 log units) below what was measured; low and high end bracket the measured number.
By their numbers in this assay, from the lowest: compounds 3, 4 and 2 (each within the scatter of the next, the first and the last beyond it). At a limit, above all of these: compound 1.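

In this assay, chloro on this aromatic carbon, para to a large group, gives a 1.9-fold higher number from compound 3 to compound 4 (0.28 log units; within the scatter) against trifluoromethoxy and a 1.5-fold lower number from compound 2 to compound 4 (0.19 log units; within the scatter) against hydrogen. Compound 4 is therefore separated from neither compound 3 nor compound 2, while those two stay apart, with a 2.9-fold lower number from compound 2 to compound 3 (0.46 log units; beyond the scatter) on record. Nothing measured here accounts for these steps.

As far as these compounds go, whether an amine, a carboxylic acid or a longer alkoxy chain on this carbon would leave the range spanned by compound 2 and compound 3 stays open. So does how chloro would read out with the oxy link of compound 1.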